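This account rests on a few compounds, and the source may have more. Where it says the series, first, only, none or still open, it means among the compounds named here.

Compound 1, `O=C(/C=C/c1ccc(OCc2nc(C3CCN(Cc4cccc(F)c4)CC3)no2)cc1)NO`, gives 73% in an assay on isolated protein for inhibition of protein deacetylase HDAC6 (Homo sapiens), read by fluorescence, with a stated time of 1 h, tested at 100 nM; a lower number here means less inhibition, a higher number more inhibition at the concentration tested (going by the name of the read-out); compound 2, `Cc1cccc(CN2CCC(c3noc(CN(C)c4ncc(C(=O)NO)cn4)n3)CC2)c1`, gives 54%.

Compound 2 stands lowest of the two numbers; its nearest neighbour, compound 1, lies higher by a margin beyond the usual scatter. Compound 3, `CN(Cc1nc(C2CCN(Cc3ccc(F)cc3Cl)CC2)no1)c1ncc(C(=O)NO)cn1`, differs from compound 2 in one place: 2-chloro-4-fluorophenyl in place of 3-methylphenyl on a saturated chain carbon bound to an amine nitrogen in a ring. Going by the values given here, no pair of measured compounds differs in a single place, so nothing measured shows the effect of such a change. In this assay the expected step is a number 1 percentage points higher from compound 2 to compound 3 (within the scatter), small and with no direction that clears the scatter. Compound 3 is therefore estimated at 55%, within 30% to 78%.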

Compound 3, a percentage reported as inhibition, at one concentration (the size of the read-out at that concentration, not a potency): 49%
Compound 3: middle estimate off by 6 percentage points, on the high side; measured number inside the range.
By their numbers in this assay, from the lowest: compounds 3 and 2 (each within the scatter of the next); then compound 1.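

In this assay, going by these compounds alone, 2-chloro-4-fluorophenyl in place of 3-methylphenyl on a saturated chain carbon bound to an amine nitrogen in a ring gives a number 5 percentage points lower from compound 2 to compound 3 (within the scatter), the first single change that can be read here. At this position, the read-out does not tell these two substituted phenyl groups apart. Nothing at hand bears on why compound 2 and compound 3 read alike.

From the compounds shown here alone, whether an unsubstituted phenyl or a cyclohexyl group at this place would read differently stays open. Also open, going by these compounds, is whether the same change would behave alike on the core of compound 1.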